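The source may hold more compounds than are shown below. What is called first, only, known or untested is meant among the compounds shown, and "the series" means these compounds.

Measured compounds in a functional assay on MCF7 cells (Homo sapiens) for inhibition; on this read-out higher numbers stand for weaker inhibition and lower numbers for stronger inhibition:

- compound 1 `CC/C(=C(/c1ccc(/C=C/C(=O)O)cc1)c1cc2ccccc2[nH]1)c1ccccc1`: 108 nM
- compound 2 `CC/C(=C(/c1ccc(/C=C/C(=O)O)cc1)c1cc2ccccc2[nH]1)c1cccc(F)c1C#N`: 40 nM
- compound 3 `CC/C(=C(/c1ccc(/C=C/C(=O)O)cc1)c1cc2ccccc2[nH]1)c1ccc(C#N)cc1Cl`: 49 nM

All three share the same core and differ only in the aromatic ring attached on a double-bonded chain carbon bound to a double-bonded chain carbon and a saturated chain carbon. Compound 3 stands second highest of the three numbers; its nearest neighbour is compound 2, and the gap between them a 1.2-fold higher number from compound 2 to compound 3 (0.09 log units; within the scatter) is within the usual scatter, so the two cannot be told apart. Its furthest neighbour is compound 1, and the step of a 2.2-fold lower number from compound 1 to compound 3 (0.34 log units; beyond the scatter) is beyond the scatter.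

Compound 4 `CC/C(=C(/c1ccc(/C=C/C(=O)O)cc1)c1cc2ccccc2[nH]1)c1ccc(Cl)c(C(F)(F)F)c1` is the next step from compound 3: 4-chloro-3-(trifluoromethyl)phenyl in place of 2-chloro-4-cyanophenyl on a double-bonded chain carbon bound to a double-bonded chain carbon and a saturated chain carbon. Among the measured compounds shown here, two measured steps bear on this position. Moving from the bare phenyl to a substituted phenyl gave a 2.7-fold lower number from compound 1 to compound 2 (0.43 log units; beyond the scatter) and a 2.2-fold lower number from compound 1 to compound 3 (0.34 log units; beyond the scatter), both modest improvements, while exchanging one substituted phenyl for another gave a 1.2-fold higher number from compound 2 to compound 3 (0.09 log units; within the scatter), which lies within the scatter. On this basis the exchange in compound 4 is expected to produce no step beyond the scatter, a 1.2-fold higher number from compound 3 to compound 4 (0.09 log units; within the scatter). Compound 4 is therefore estimated at 60 nM in this assay, with a range from 25 nM to 150 nM.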

Compound 4, half-maximal inhibitory concentration: 2200 nM
Estimate against measurement, compound 4: 37-fold (1.56 log units) below; the measured number lies above the stated range.
By their numbers in this assay, from the lowest: compounds 2 and 3 (each within the scatter of the next); then compound 1; then compound 4.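

In this assay this position turns out to be far from forgiving: exchanging one substituted phenyl ring for another can cost a great deal, with a 45-fold higher number from compound 3 to compound 4 (1.65 log units; beyond the scatter) here and a 55-fold higher number from compound 2 to compound 4 (1.74 log units; beyond the scatter) against the other nitrile-bearing ring. Substitution is no gain in itself either, as a 20-fold higher number from compound 1 to compound 4 (1.31 log units; beyond the scatter) places the new ring behind even the bare phenyl, and chlorine alone does not keep the number low, as both compound 3 and compound 4 carry it; among these four compounds, only the rings with a nitrile improve on phenyl. Nothing available here explains the loss.

The exchange also does several things at once, removing the nitrile, adding trifluoromethyl and changing the 2-chloro ring to a 4-chloro ring, so the compounds shown cannot say which of these matters most. Still open, on these data alone, is how a phenyl ring carrying trifluoromethyl alone, nitrile alone or a methoxy group would behave at this position, and whether adding a nitrile to the ring of compound 4 would recover the lost inhibition.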